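Phenoxy in Place of Chloro on the Benzyl Ring

A few compounds are considered here, and "the series" means these few. Any claim that something is new, unique, unknown or untested is made for them only; others in the source may bear on it.

For the measured compounds named here, compound 2 `Cc1cc(CCC(=O)O)ccc1OCc1cccc(Cl)c1` gives 60% in a functional assay on cells for agonist activity at Free fatty acid receptor 1 (Homo sapiens), read by FLIPR and calcium flux (a higher number here means a larger maximal response, a lower number a smaller maximal response), the lower of the two measured numbers; compound 1 `Cc1cc(CCC(=O)O)ccc1OCc1ccccc1Cl` gives 80% in this assay, and the step of a number 20 percentage points lower from compound 1 to compound 2 (beyond the scatter) is the only measured comparison. Compound 3 `Cc1cc(CCC(=O)O)ccc1OCc1cccc(Oc2ccccc2)c1` differs from compound 2 by phenoxy in place of chloro on an aromatic carbon. Going by the values given here, no measured step involves a phenoxy group, so the single known step speaks to a different change and offers little guidance here. The expected step is therefore a number 5 percentage points higher from compound 2 to compound 3 (within the scatter), within the scatter. Compound 3 is estimated at 65%, with a range from 40% to 90%.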

Compound 3, largest response reached (reported as percent of maximum), in percent of the reference or control that the assay uses: 90%
Estimate against measurement, compound 3: 25 percentage points below; the range from low to high includes it.
By their numbers in this assay, from the lowest: compound 2; then compounds 1 and 3 (each within the scatter of the next).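

In this assay, the step of a number 30 percentage points higher from compound 2 to compound 3 (beyond the scatter) shows that this position, meta to a large group, tolerates much more than a single chlorine: phenoxy brings seven heavy atoms and a whole aromatic ring, yet the maximal response rises rather than falls. Nothing available explains this rise. 

Open, as far as these compounds go, is whether the added ring itself matters, since a methoxy group or an amine in place of phenoxy would help separate the ring from its oxygen link. Also open, from the compounds shown here alone, is how phenoxy would behave where compound 1 carries its chlorine.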